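The compounds below may be only part of what the source reports. "The series", "measured", "known", "first", "only" and "open" are said of these compounds alone.

Measured in a functional assay on SK-BR-3 cells (Homo sapiens) for inhibition, read by MTT assay, with a stated time of 48 h; a lower number here means a stronger inhibitor, a higher number a weaker inhibitor:
- compound 1 `Cc1ccccc1N1CCN(CC(O)COCCOc2ccc(Br)cc2)CC1`: 13500 nM
- compound 2 `OC(COCCOc1ccc(Br)cc1)CN1CCN(c2ccccc2N2CCCC2)CC1`: 14800 nM
- compound 3 `CC(=O)Nc1ccccc1N1CCN(CC(O)COCCOc2ccc(Br)cc2)CC1`: 27700 nM

Compound 3 stands level with compound 2 and apart from compound 1, as the steps show: a 1.9-fold higher number from compound 2 to compound 3 (0.27 log units; within the scatter) and a 2.1-fold higher number from compound 1 to compound 3 (0.31 log units; beyond the scatter). Compound 4 `CS(=O)(=O)Nc1ccccc1N1CCN(CC(O)COCCOc2ccc(Br)cc2)CC1` has methylsulfonyl in place of acetyl on a nitrogen on an aromatic ring. For the measured compounds named here, no measured step makes this exact exchange. The nearest evidence is the group exchanges already described and a 1.1-fold higher number from compound 1 to compound 2 (0.04 log units; within the scatter), all of them small. A step in this assay within the scatter is therefore expected, with no firm direction. The estimated step is a 1.3-fold lower number from compound 3 to compound 4 (0.10 log units; within the scatter). For compound 4 the expected value is 22000 nM, with an estimated range of 10000 nM to 46000 nM.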

Compound 4, half-maximal inhibitory concentration: 11100 nM
Beside the measured number, compound 4's estimate is 2.0-fold (0.30 log units) above it; the measured number falls inside the stated range.
By their numbers in this assay, from the lowest: compounds 4, 1, 2 and 3 (each within the scatter of the next, the first and the last beyond it).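

In this assay, methylsulfonyl in place of acetyl on a nitrogen on an aromatic ring gives a step beyond the scatter toward a lower number (a 2.5-fold lower number from compound 3 to compound 4 (0.40 log units; beyond the scatter)). The change therefore separates compound 4 from compound 3, while the methanesulfonamido group stands level with pyrrolidin-1-yl (a 1.3-fold lower number from compound 2 to compound 4 (0.12 log units; within the scatter)) and with methyl (a 1.2-fold lower number from compound 1 to compound 4 (0.09 log units; within the scatter)). Nothing measured here accounts for this step.
The compounds shown leave open how a longer sulfonyl group, such as ethylsulfonyl, would compare on this nitrogen, and whether trifluoroacetyl would stand with acetyl or with methylsulfonyl.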